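The source may hold more compounds than are shown below. What is called first, only, known or untested is meant among the compounds shown, and "the series" means these compounds.

Compound 1 `O=C(O)Cn1nc(CC(=O)Nc2ccc(OC(F)(F)F)c(Cl)c2)c2ccccc2c1=O` is the lower of the two numbers recorded in a functional assay on CHO cells for antagonist activity at sphingosine 1-phosphate receptor 2 (Homo sapiens), read by GTPgammaS binding (on this read-out lower numbers stand for stronger inhibition and higher numbers for weaker inhibition), where compound 1 gives 754 nM. Compound 2 `COc1cc(OC)c(NC(=O)Cn2nc(CC(=O)O)c3ccccc32)cc1Cl` gives 8980 nM in this assay, a weaker result that sits beyond the scatter of compound 1. Compound 3 `CCn1nc(CC(=O)Nc2ccc(OC(F)(F)F)c(Cl)c2)c2ccccc2c1=O` has not been measured; it differs from compound 1 by methyl in place of carboxy on a saturated chain carbon bound to an aromatic nitrogen. For the measured compounds named here, with no measured pair showing this change, a modest loss of potency is expected, so that compound 3 is estimated at 1500 nM in this assay, within 400 nM to 6000 nM, a step of a 2.0-fold higher number from compound 1 to compound 3 (0.30 log units; within the scatter).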

Compound 3, half-maximal inhibitory concentration: 473 nM
For compound 3 the middle estimate is 3.2-fold (0.50 log units) above the measured one; measured number inside the range.
By their numbers in this assay, from the lowest: compounds 3 and 1 (each within the scatter of the next); then compound 2.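

In this assay, replacing carboxy with methyl on a saturated chain carbon bound to an aromatic nitrogen gives a 1.6-fold lower number from compound 1 to compound 3 (0.20 log units; within the scatter). The carboxy group at this place can therefore be lost, along with its hydrogen-bond donor and acceptor, without the number leaving the scatter. Going by these compounds, whether an amine, a hydroxyl group or a longer chain at this place would also stay within the scatter remains open. So does whether the same change would read alike with other groups on the amide. No measurement at hand accounts for this result.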